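Shortening the side chain back toward an oxygen ether

The compounds below may be only part of what the source reports. "The series", "measured", "known", "first", "only" and "open" are said of these compounds alone.

Compound 1 `CCNCCn1c(N2CCN(C)CC2)nc2ccccc21` gives 290 nM in a functional assay on ileum for inhibition of histamine H1 receptor (Cavia porcellus); a lower number here means a stronger inhibitor, a higher number a weaker inhibitor.
Compound 2 `CCSCCn1c(N2CCN(C)CC2)nc2ccccc21` gives 19 nM in this assay.
Compound 3 `CCSCCCn1c(N2CCN(C)CC2)nc2ccccc21` gives 530 nM in this assay.

Compound 3 stands highest of the three numbers: it is within the scatter of compound 1, while it lies far from compound 2, the step being a 28-fold higher number from compound 2 to compound 3 (1.45 log units; beyond the scatter). Compound 4 `COCCn1c(N2CCN(C)CC2)nc2ccccc21` differs from compound 3 by methoxy in place of (ethylsulfanyl)methyl on a saturated chain carbon, two bonds along the chain from an aromatic nitrogen; cut one bond further out, the same change reads 3-(ethylsulfanyl)propyl to 2-methoxyethyl, so compound 4 carries the two-bond spacing of compounds 1 and 2 rather than the longer chain of compound 3. The step that bears most directly on it is a 28-fold higher number from compound 2 to compound 3 (1.45 log units; beyond the scatter), which shows what lengthening the chain cost; the step of a 15-fold lower number from compound 1 to compound 2 (1.18 log units; beyond the scatter) shows how much the terminal heteroatom itself can shift the number at that spacing. Compound 4 is therefore expected to come in clearly lower than compound 3, with the estimated step of a 5.3-fold lower number from compound 3 to compound 4 (0.72 log units; beyond the scatter). The estimate for compound 4 is 100 nM, with a range from 25 nM to 400 nM.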

Compound 4, half-maximal inhibitory concentration: 13 nM
Compound 4: the middle estimate sits 7.7-fold (0.89 log units) above what was measured, outside the stated range (below it).
By their numbers in this assay, from the lowest: compounds 4 and 2 (each within the scatter of the next); then compounds 1 and 3 (each within the scatter of the next).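

At the place two bonds along the chain from an aromatic nitrogen, methoxy and ethylsulfanyl could not be told apart in this assay, with a 1.5-fold lower number from compound 2 to compound 4 (0.16 log units; within the scatter) within the scatter. Of the three groups at this spacing, ethylamino is the one that stands apart: the ethylsulfanyl of compound 2 already showed this, and a 22-fold lower number from compound 1 to compound 4 (1.35 log units; beyond the scatter) shows that it also holds for methoxy. The step is large at a 41-fold lower number from compound 3 to compound 4 (1.61 log units; beyond the scatter). Of a similar size is a 28-fold higher number from compound 2 to compound 3 (1.45 log units; beyond the scatter), so among these compounds the higher number goes with the 3-(ethylsulfanyl)propyl chain and not with sulfur as such.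

As far as these compounds go, it remains open whether a 3-methoxypropyl chain would pay the same penalty, and whether an ethoxy or a hydroxyl group would match methoxy at the shorter spacing. Nothing given here accounts for these differences.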